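The compounds below may be only part of what the source reports. "The series", "measured", "known", "first", "only" and "open" are said of these compounds alone.

Going by the values given here, in an ADME assay on MDCK cells (Canis lupus familiaris) for cytotoxicity, with a stated time of 48 h (on this read-out lower numbers stand for higher toxicity in this test and higher numbers for lower toxicity in this test), compound 1 `CCC(CC)O[C@@H]1C=C(C(=O)Nc2ccccc2)C[C@H](N)[C@H]1NC(C)=O` gives 151000 nM, the only true number in this small set. Compound 2 `CCC(CC)O[C@@H]1C=C(C(=O)Nc2ccccc2OC)C[C@H](NC(=O)OC(C)(C)C)[C@H]1NC(C)=O` reads > 1000000 nM, which is a limit and not a number. Compound 3 `CCC(CC)O[C@@H]1C=C(C(=O)Nc2ccccc2)C[C@H](NC(=O)OC(C)(C)C)[C@H]1NC(C)=O` reads > 1000000 nM, which is also a limit. Compound 4 `CCC(CC)O[C@@H]1C=C(C(=O)Nc2ccccc2OC)C[C@H](N)[C@H]1NC(C)=O` has not yet been measured. It differs from compound 1 by methoxy in place of hydrogen on an aromatic carbon, ortho to a large group.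

Among the compounds with values here, two measured steps bear on this change. Putting tert-butoxycarbonyl in place of hydrogen on the amine nitrogen gives an at least 6.6-fold higher number from compound 1 to compound 3 (0.82 log units; beyond the scatter), but compound 4 keeps that hydrogen, so this step concerns a different site. The same methoxy swap, seen in reverse, appears as a step that the two limits leave unreadable from compound 2 to compound 3, which gives no size because of the limit of > 1000000 nM in this assay, at which 2 of the 3 values shown sit. Nothing measured therefore points to a shift, and no change beyond the scatter is expected in this assay. The expected result is a 1.2-fold higher number from compound 1 to compound 4 (0.08 log units; within the scatter). For compound 4 the estimate is 180000 nM, with an expected range from 60000 nM to 550000 nM.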

Compound 4, half-maximal cytotoxic concentration: 35300 nM
Compound 4: middle estimate off by 5.1-fold (0.71 log units), on the high side, and the stated range ends above it.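

The position is not neutral after all: in this assay, going from phenyl to 2-methoxyphenyl with the free amine in place gives a 4.3-fold lower number from compound 1 to compound 4 (0.63 log units; beyond the scatter). Removing the tert-butoxycarbonyl group from the methoxy-bearing compound gives an at least 28-fold lower number from compound 2 to compound 4 (1.45 log units; beyond the scatter), so the change at the amine nitrogen now points the same way on two cores: the same change on two cores in this assay, an at least 6.6-fold higher number (0.82 log units; beyond the scatter) from compound 1 to compound 3 and an at least 28-fold higher number (1.45 log units; beyond the scatter) from compound 4 to compound 2; the limit leaves it open whether they differ The same methoxy swap with tert-butoxycarbonyl on the nitrogen cannot be read, because both values there are limits: the limit of > 1000000 nM in this assay, at which 2 of the 4 values shown sit.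

The methoxy step therefore rests on a single readable pair. As far as these compounds go, whether a fluorine, a hydroxyl or an ethoxy on that same aromatic carbon would also lower the number remains open, as does the effect of methoxy on another carbon of the ring.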